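The source may report more compounds than this note shows. Statements on the series, on what has been measured and on what is new or still open speak of the compounds shown alone.

Among the measured compounds shown here, only two compounds have been measured so far in an ADME assay on HT-29 cells (Homo sapiens) for inhibition, read by trypan blue exclusion, with a stated time of 72 h; on this read-out higher numbers stand for weaker inhibition of growth and lower numbers for stronger inhibition of growth. Compound 1 (`O=C(/C=C/c1ccccc1)c1cccc([N+](=O)[O-])c1`) gives 9000 nM, and compound 2 (`O=C(/C=C/c1cccc([N+](=O)[O-])c1)c1ccccc1`) gives 5000 nM. For the measured compounds named here, these two values lie within the usual scatter of each other, so compound 1 cannot be ranked against the only other compound measured. Both compounds carry a nitro group, placed differently on the shared core.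

Compound 3 (`O=C(/C=C/c1ccccc1)c1cccc(C(F)(F)F)c1`) keeps the core of compound 1 and alters one group: trifluoromethyl in place of nitro on an aromatic carbon. Trifluoromethyl thus takes the place of nitro on an aromatic carbon, meta to a large group. Going by the values given here, no measured pair shows this replacement, so the data give no direct guide to its size or direction. With nothing to set a direction, no step beyond the scatter is expected in this assay. The expected change is a 1.1-fold lower number from compound 1 to compound 3 (0.05 log units; within the scatter), a small estimate that carries little weight given how few measurements support it. Compound 3 is estimated to give 8000 nM, with an expected range of 3000 nM to 20000 nM.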

Compound 3, concentration for 50% growth inhibition: > 20000 nM
Compound 3: only a limit was reported; the forecaster's own chance of this, stated with the estimate: 10%; at least 2.5-fold (0.39 log units) between middle value and limit.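

In this assay compound 3 gives > 20000 nM, which is a limit of the assay and not a number. Trifluoromethyl in place of nitro on an aromatic carbon, meta to a large group, gives an at least 2.2-fold higher number from compound 1 to compound 3 (0.34 log units; beyond the scatter), so this position is not indifferent to the group it carries, and here the nitro compound shows the stronger inhibition of growth. The earlier pair could not show this, as its two values lay within the scatter of each other, and the new step is itself only a minimum whose full size cannot be read: the limit of > 20000 nM in this assay, at which 1 of the 3 values shown sits.

The compounds shown do not tell whether the change follows from losing the nitro group or from bringing in trifluoromethyl, or whether an amine, a nitrile or a carboxylic acid on the same aromatic carbon would keep the inhibition seen with compound 1. They also leave open whether trifluoromethyl in place of the nitro group of compound 2, on the other aromatic ring of the shared core, would move the number in the same direction.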